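Dropping One Methoxy Group from Compound 3

A few compounds are considered here, and "the series" means these few. Any claim that something is new, unique, unknown or untested is made for them only; others in the source may bear on it.

Measured so far:
compound 1, `CCNc1ccc2c(c1)OC(N)=C(C#N)C2c1cccc([N+](=O)[O-])c1`: 110000000 nM
compound 2, `N#CC1=C(N)Oc2c(ccc(N)c2N)C1c1cccc(C#N)c1`: 390000000 nM
compound 3, `CCNc1ccc2c(c1)OC(N)=C(C#N)C2c1cc(OC)c(OC)c(OC)c1`: 49000000 nM

In a functional assay on T47D cells (Homo sapiens) for activation (a higher number here means that more compound is needed for the effect, a lower number that less compound is needed), compound 3 stands at the lowest number of the three. Compound 1 follows at 110000000 nM, a gap beyond the usual scatter, and compound 2 lies furthest away at 390000000 nM. Compound 4, `CCNc1ccc2c(c1)OC(N)=C(C#N)C2c1cc(OC)cc(OC)c1`, differs from compound 3 only by hydrogen in place of methoxy on an aromatic carbon. For the measured compounds named here, no pair of measured compounds shows this exact change, so its direction cannot be read from the data. The expected step is a 1.2-fold higher number from compound 3 to compound 4 (0.09 log units; within the scatter), modest and in either direction. Compound 4 is estimated to give about 60000000 nM, within a range from 20000000 nM to 200000000 nM.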

Compound 4, half-maximal effective concentration: 61700000 nM
Compound 4: middle estimate off by 1.0-fold (0.01 log units), on the low side, and the stated range covers the measured number.
By their numbers in this assay, from the lowest: compounds 3, 4 and 1 (each within the scatter of the next, the first and the last beyond it); then compound 2.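

In this assay, for the compounds shown here, the reading at this position is a 1.3-fold higher number from compound 3 to compound 4 (0.10 log units; within the scatter) and gives the first direct look at hydrogen in place of methoxy on an aromatic carbon. Compound 3 and compound 4 cannot be told apart, so in this pair the methoxy group para to a large group is not needed to reach this level. No outside measurement on this pair helps to explain the result.

From the compounds shown here alone, whether an amine or a carboxylic acid on this carbon would behave alike stays open. So does the effect of removing either of the two remaining methoxy groups.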